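A few compounds are considered here, and "the series" means these few. Any claim that something is new, unique, unknown or untested is made for them only; others in the source may bear on it.

Compound 1 `Cc1cn([C@@H]2O[C@H](CO[Si](C)(C)C(C)(C)C)[C@@]3(OS(=O)(=O)C=C3NCC(=O)O)[C@H]2O[Si](C)(C)C(C)(C)C)c(=O)n(C)c1=O` is the starting point of this account. Among the measured compounds shown here, in a functional assay on MT4 cells (Homo sapiens) (a higher number here means that more compound is tolerated, a lower number that less compound is tolerated), compound 1 gives 30000 nM, the highest of the three numbers so far measured. Its two measured neighbours, compound 2 `CCOC(=O)CNC(=O)NC1=CS(=O)(=O)O[C@@]12[C@@H](CO[Si](C)(C)C(C)(C)C)O[C@@H](n1cc(C)c(=O)n(C)c1=O)[C@@H]2O[Si](C)(C)C(C)(C)C` with 3780 nM and compound 3 `Cc1cn([C@@H]2O[C@H](CO[Si](C)(C)C(C)(C)C)[C@@]3(OS(=O)(=O)C=C3NC(=O)c3ccccc3)[C@H]2O[Si](C)(C)C(C)(C)C)c(=O)n(C)c1=O` with 4900 nM, both sit well apart from it: a 7.9-fold lower number from compound 1 to compound 2 (0.90 log units; beyond the scatter) and a 6.1-fold lower number from compound 1 to compound 3 (0.79 log units; beyond the scatter). Between these two neighbours themselves the difference is small, a 1.3-fold higher number from compound 2 to compound 3 (0.11 log units; within the scatter), so their numbers cannot be told apart.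

Compound 4 `Cc1cn([C@@H]2O[C@H](CO[Si](C)(C)C(C)(C)C)[C@@]3(OS(=O)(=O)C=C3NCC(=O)C(N)=O)[C@H]2O[Si](C)(C)C(C)(C)C)c(=O)n(C)c1=O` has not yet been measured. It differs from compound 1 in one place: carbamoyl in place of hydroxy on a carbonyl carbon. The carboxy group thus becomes a carbamoylcarbonyl group while the rest of the molecule is kept.

The two measured steps that bear on this change are those leaving compound 1, and both replace the carboxymethyl group on the amine nitrogen with something lacking the carboxy group, each time giving a modestly lower number in this assay. The change to compound 4 is smaller, touching only the carboxy group itself, so the step is expected to be smaller than either measured step and in the same direction, estimated as a 2.5-fold lower number from compound 1 to compound 4 (0.40 log units; beyond the scatter). Compound 4 is therefore estimated at 12000 nM in this assay, within a range from 4000 nM to 35000 nM.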

Compound 4, half-maximal cytotoxic concentration: 9590 nM
Compound 4: middle estimate off by 1.3-fold (0.10 log units), on the high side; measured number inside the range.
By their numbers in this assay, from the lowest: compounds 2, 3 and 4 (each within the scatter of the next, the first and the last beyond it); then compound 1.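

In this assay, the carboxymethyl group on the amine nitrogen need not be replaced as a whole for the number to move: carbamoyl in place of hydroxy on a carbonyl carbon, with the rest of the molecule kept, gives a 3.1-fold lower number from compound 1 to compound 4 (0.50 log units; beyond the scatter). This change therefore places the new compound apart from the carboxy parent, with a 2.0-fold higher number from compound 3 to compound 4 (0.29 log units; within the scatter), so the carbamoylcarbonyl and benzoyl compounds cannot be told apart, while a 2.5-fold higher number from compound 2 to compound 4 (0.40 log units; beyond the scatter) leaves a modest separation from the ethoxycarbonyl-bearing compound. No measured evidence is available to account for any of these steps.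

The compounds shown leave open whether the step depends on the particular group that enters, since an ethyl ester or a methyl ketone on the same carbonyl carbon would test whether other replacements for hydroxy give a similar number. They also leave open how far the result holds for a longer chain between the amine nitrogen and the carbonyl carbon, as every compound here carries the same shared core and protecting silyl groups.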